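The compounds below may be only part of what the source reports. "The series", "measured", "known", "first", "only" and "open" are said of these compounds alone.

Three compounds share one core and differ only in the group sitting on an oxygen next to a carbonyl group. Compound 1 `CCc1ccc(OC(=O)c2cn(-c3ccccc3)nc2-c2ccncc2)cc1` gave "nd(insoluble)" (no result reported) in a functional assay on MCF7 cells (Homo sapiens) for cytotoxicity, read by MTT assay, with a stated time of 48 h (on this read-out higher numbers stand for weaker inhibition and lower numbers for stronger inhibition), so no number stands for it. Compound 2 `CC(C)(C)c1ccc(OC(=O)c2cn(-c3ccccc3)nc2-c2ccncc2)cc1` gives 32300 nM in this assay, and compound 3 `O=C(Oc1ccc2ccccc2c1)c1cn(-c2ccccc2)nc1-c1ccncc1` gives 44500 nM; with a 1.4-fold higher number from compound 2 to compound 3 (0.14 log units; within the scatter) within the scatter, compound 3 holds the higher of two numbers without real separation from compound 2. Compound 4 `O=C(O)c1cn(-c2ccccc2)nc1-c1ccncc1` differs from compound 3 in that (hydrogen in place of naphthalen-2-yl on an oxygen next to a carbonyl group). Among the measured compounds shown here, no measured step mirrors this change, and the one available step swapped one ring group for another without moving the number. For compound 4 the expected step is therefore a 1.1-fold higher number from compound 3 to compound 4 (0.05 log units; within the scatter), with no direction expected beyond the scatter. The estimate for compound 4 is 50000 nM, expected to lie between 15000 nM and 200000 nM.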

Compound 4, half-maximal inhibitory concentration: > 100000 nM
Compound 4 ended at the assay's limit; the forecaster's own chance of this, stated with the estimate: 30%; middle value at least 2.0-fold (0.30 log units) away from the limit.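

Hydrogen on an oxygen next to a carbonyl group marks the first real shift at this position, unlike the earlier swap of one ring group for another: an at least 2.2-fold higher number from compound 3 to compound 4 (0.35 log units; beyond the scatter), and an at least 3.0-fold higher number from compound 2 to compound 4 (0.49 log units; beyond the scatter). In this assay, a ring group on this oxygen therefore goes with a readable number, while hydrogen does not. Compound 4 has a limit rather than a number: the limit of > 100000 nM in this assay, at which 1 of the 4 values shown sits.

The compounds shown leave open whether a small group, such as methyl or plain phenyl, would be enough to keep a readable number. On these data alone, how far compound 4 truly lies from its limit also remains open.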